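A Methoxy Group Tried on a Second Core

The source may report more compounds than this note shows. Statements on the series, on what has been measured and on what is new or still open speak of the compounds shown alone.

Of the compounds shown here, three have been measured in a functional assay on FM3A cells (Mus musculus) for inhibition, read by cell counting, with a stated time of 2 days; on this read-out higher numbers stand for weaker inhibition and lower numbers for stronger inhibition. Compound 1 `COc1ccc(-c2nn3cc(-c4cccc(N)c4)nc3s2)cc1OC` gives 13000 nM. Compound 2 `Nc1cccc(-c2cn3c(-c4ccccc4)csc3n2)c1`, which carries a different core, gives 34000 nM. Built on the same core as compound 1, compound 3 `COc1ccc(-c2nn3cc(-c4cccc(N)c4)nc3s2)cc1` gives 74000 nM. The difference between the core of compound 2 and the core of compound 3 is not broken down here; the two also differ in their outer groups, so their two values can only be set side by side.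

Within the first core, one change is measured: methoxy in place of hydrogen on an aromatic carbon gives a 5.7-fold lower number from compound 3 to compound 1 (0.76 log units; beyond the scatter). The unmeasured compound 4 `COc1ccc(-c2csc3nc(-c4cccc(N)c4)cn23)cc1` is related to compound 2 by the same kind of change, (methoxy in place of hydrogen on an aromatic carbon), but the place is not the same. In the measured pair the entering group sits ortho to a methoxy group and meta to a large group; in the new pair it sits para to a large group, and no methoxy group is already present on that ring.

Among the measured compounds shown here, compound 4 is therefore expected to move in the same direction as the measured pair, and the expected step is a smaller one, a 2.0-fold lower number from compound 2 to compound 4 (0.30 log units; within the scatter), since the surroundings of the new group differ and only the one step in compound 3 to compound 1 supports the direction. The estimate for compound 4 in this assay is 17000 nM, with a range from 6000 nM to 50000 nM.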

Compound 4, half-maximal inhibitory concentration: 11000 nM
Compound 4: middle estimate off by 1.5-fold (0.19 log units), on the high side; the range from low to high includes it.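

In this assay, methoxy in place of hydrogen on an aromatic carbon gives a 3.1-fold lower number from compound 2 to compound 4 (0.49 log units; beyond the scatter), so the number falls on this second core as it did on the first. The sizes of the two steps cannot be told apart, since the gap between them is no larger than two such steps would show through ordinary scatter alone: the same change on two cores in this assay, a 5.7-fold lower number (0.76 log units; beyond the scatter) from compound 3 to compound 1 and a 3.1-fold lower number (0.49 log units; beyond the scatter) from compound 2 to compound 4, 1.8-fold (0.27 log units) apart, within the scatter of two such steps. Among the compounds shown here, this shows the same direction on two cores, but it rests on only two pairs in which the methoxy group also stands in different surroundings, so it gives no rule for other cores or other places on the ring, and it does not explain why the number falls.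

The compounds shown leave open whether a second methoxy group on the same ring of compound 4 would lower the number again, as the added methoxy group did on the way to compound 1 on the first core. They also leave open whether a different group at the place taken by methoxy in compound 4, such as an ethoxy group, a hydroxyl group or a fluorine atom, would move the number in the same direction.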